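Chloro on the aryl ring: a small para-substituent step

The compounds below may be only part of what the source reports. "The series", "measured", "known", "first", "only" and "open" are said of these compounds alone.

Compound 2 `O=C(CN1CCCCC1)N1N=C(c2ccccc2)CC1c1ccccc1O` and compound 1 `COc1ccc(C2=NN(C(=O)CN3CCCCC3)C(c3ccccc3O)C2)cc1` share one core and differ only in a methoxy group. In an assay on isolated protein for inhibition of Amine oxidase [flavin-containing] B (Homo sapiens), read by fluorescence, with stated times of 15 min and 20 min (on this read-out higher numbers stand for weaker inhibition and lower numbers for stronger inhibition), compound 2 gives 50600 nM and compound 1 gives 59400 nM, two numbers that sit within the scatter of each other; the step of a 1.2-fold lower number from compound 1 to compound 2 (0.07 log units; within the scatter) is therefore no real change. Compound 3 `O=C(CN1CCCCC1)N1N=C(c2ccc(Cl)cc2)CC1c1ccccc1O`, not yet measured, carries chloro in place of hydrogen on an aromatic carbon. Among the measured compounds shown here, the only measured step touches the same aromatic carbon and is within the scatter, so for compound 3 the step of a 1.1-fold lower number from compound 2 to compound 3 (0.05 log units; within the scatter) is expected to stay within the scatter as well. Compound 3 is estimated at 45000 nM, between 20000 nM and 110000 nM.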

Compound 3, half-maximal inhibitory concentration: 40100 nM
Beside the measured number, compound 3's estimate is 1.1-fold (0.05 log units) above it, and the stated range covers the measured number.
By their numbers in this assay, from the lowest: compounds 3, 2 and 1 (each within the scatter of the next).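

Chloro now joins hydrogen and methoxy on this same aromatic carbon, and in this assay there is a 1.3-fold lower number from compound 2 to compound 3 (0.10 log units; within the scatter) and also a 1.5-fold lower number from compound 1 to compound 3 (0.17 log units; within the scatter), so neither step counts as a real change. Across these three groups, then, the swap at this carbon has so far made no difference that the assay can resolve. No measured evidence here bears on why these numbers stay so close. On these data alone, whether an amine, a carboxylic acid or a longer chain on this carbon would produce a step beyond the scatter remains open.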